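This account rests on a few compounds, and the source may have more. Where it says the series, first, only, none or still open, it means among the compounds named here.

Working notes on the series. Compound 1 `COc1cc2nc(N3CCN(C(=O)c4ccc[nH]4)[C@H]4CCCC[C@H]43)nc(N)c2cc1OC` and compound 2 `COc1cc2nc(N3CCN(C(=O)c4ccccn4)[C@H]4CCCC[C@H]43)nc(N)c2cc1OC` share one core and differ only in the group on the carbonyl carbon. In an assay on CHO cells for displacement of a labelled ligand from Alpha-1A adrenergic receptor (Homo sapiens) (a higher number here means a weaker inhibitor, a lower number a stronger inhibitor), compound 1 gives 10.5 nM, and in this assay compound 2 gives 49 nM. Among the measured compounds shown here, the only step measured so far, a 4.7-fold higher number from compound 1 to compound 2 (0.67 log units; beyond the scatter), is the sole reference point. Compound 2 thus stands at the higher of the two numbers recorded, with compound 1 as its nearest neighbour.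

The next compound, compound 3 `COc1cc2nc(N3CCN(C(=O)c4ccccc4)[C@H]4CCCC[C@H]43)nc(N)c2cc1OC`, again changes only the group on the carbonyl carbon: phenyl in place of pyridin-2-yl on a carbonyl carbon. For the measured compounds named here, no measured step covers removal of the ring nitrogen from this position; the step from compound 1 to compound 2 concerns a different pair of rings, so it bears on the present change only loosely, showing that the group on the carbonyl carbon can shift this assay by a modest amount. A step of similar or smaller size is therefore expected here, direction uncertain.

Compound 3 is estimated at 35 nM in this assay, with a range of 9 nM to 140 nM. This estimate means a step of a 1.4-fold lower number from compound 2 to compound 3 (0.15 log units; within the scatter) is expected.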

Compound 3, inhibition constant: 4.17 nM
Compound 3: middle estimate off by 8.4-fold (0.92 log units), on the high side, and the stated range ends above it.
By their numbers in this assay, from the lowest: compound 3; then compound 1; then compound 2.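

In this assay, among the compounds shown here, exchanging pyridin-2-yl for phenyl on a carbonyl carbon keeps the count of heavy atoms and replaces only the single ring nitrogen with carbon, yet it gives a 12-fold lower number from compound 2 to compound 3 (1.07 log units; beyond the scatter), the first step graded large. The position is therefore sensitive to a change of one ring atom, more so than the earlier step between the two heteroaromatic rings suggested. Phenyl also compares favourably with the other ring, with a 2.5-fold lower number from compound 1 to compound 3 (0.40 log units; beyond the scatter), so compound 3 is the strongest of the three, and a ring hydrogen-bond donor or acceptor is not required for a low number here, although nothing measured on these compounds accounts for the size of either step.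

The compounds shown leave open whether the loss seen with pyridin-2-yl follows the ring nitrogen wherever it stands, which a pyridin-3-yl or pyridin-4-yl group on the same carbonyl carbon would test. They also leave open whether an aromatic ring is needed at all, and how far the phenyl ring tolerates added groups, questions that a cyclohexyl group or a methoxy or fluoro substituent on the phenyl would address.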